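A few compounds are considered here, and "the series" means these few. Any claim that something is new, unique, unknown or untested is made for them only; others in the source may bear on it.

Working notes on the series. All members share one core, with a five-membered aromatic ring attached on an aromatic carbon of it; compound 1 `Nc1nc(N)c2c(-c3ccsc3)cn([C@@H]3O[C@H](CO)[C@@H](O)[C@H]3O)c2n1` carries thiophen-3-yl there. In a functional assay on HeLa S3 cells (Homo sapiens) for antiproliferative activity, read by XTT assay, with a stated time of 72 h (a higher number here means a weaker inhibitor, a lower number a stronger inhibitor), compound 1 gives > 20000 nM, which is a limit of the assay and not a number. Compound 2 `O=c1[nH]cnc2c1c(-c1ccsc1)cn2[C@@H]1O[C@H](CO)[C@@H](O)[C@H]1O` keeps thiophen-3-yl and alters the core. In this assay compound 2 gives > 20000 nM, again a limit. Compound 3 `Cc1nc(N)c2c(-c3ccsc3)cn([C@@H]3O[C@H](CO)[C@@H](O)[C@H]3O)c2n1` carries methyl in place of amino on an aromatic carbon of the core. In this assay compound 3 gives > 20000 nM, also a limit. The step that the two limits leave unreadable from compound 1 to compound 3 cannot be sized because the limit of > 20000 nM in this assay, at which 3 of the 3 values shown sit, is where all three measured values sit. Compound 1 thus stands at that limit together with the other two, and no order among them is readable.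

Compound 4 `Nc1nc(N)c2c(-c3ccco3)cn([C@@H]3O[C@H](CO)[C@@H](O)[C@H]3O)c2n1` differs from compound 1 in one place: furan-2-yl in place of thiophen-3-yl on an aromatic carbon. Within the data shown here, no measured step touches this position, and the one measured step is itself unreadable, so the numbers give no direction or size for the change in this assay. With every neighbour at the limit, compound 4 is expected to give 30000 nM, between 15000 nM and 100000 nM, most likely reported as a limit as well. The step that the limit leaves unreadable from compound 1 to compound 4 is accordingly expected to stay within the scatter, though the limit would leave even that unreadable.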

Compound 4, half-maximal inhibitory concentration: > 20000 nM
Compound 4: only a limit was reported; the forecaster's own chance of this, stated with the estimate: 85%; the middle value does not contradict the limit.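

In this assay compound 4 gives > 20000 nM, again a limit and not a number. Among these compounds, no step from compound 1 to compound 4 can be read, because all the values sit together: the limit of > 20000 nM in this assay, at which 4 of the 4 values shown sit. The compounds shown leave open whether any change to the five-membered aromatic ring or the shared core affects antiproliferative activity.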